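Compound 4 and a Limit That Hides Every Step

The compounds below may be only part of what the source reports. "The series", "measured", "known", "first", "only" and "open" are said of these compounds alone.

Three relatives sharing one core have been tested in a functional assay (blood) for inhibition, with Homo sapiens as the target (on this read-out lower numbers stand for stronger inhibition and higher numbers for weaker inhibition), and none has yet given a number. Compound 2 (`CC(C)(C)Sc1c(CC(C)(C)C(=O)O)n(Cc2ccc(Cl)cc2)c2ccc(OCc3ccc4cc(F)c(F)cc4n3)cc12`) stands at > 3000 nM, which is a limit of the assay and not a measured value. Compound 1 (`CCCC(Oc1ccc2c(c1)c(SC(C)(C)C)c(CC(C)(C)C(=O)O)n2Cc1ccc(Cl)cc1)c1ccc2ccccc2n1`) gives > 3000 nM, which is also a limit. Compound 3 (`CC(C)(C)Sc1c(CC(C)(C)C(=O)O)n(Cc2ccc(Cl)cc2)c2ccc(OCc3cc4ccccc4cn3)cc12`) gives > 3000 nM, again a limit. Within the data shown here, the series so far therefore comes down to one observation: the limit of > 3000 nM in this assay, at which 3 of the 3 values shown sit.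

Compound 4 (`CC(C)(C)Sc1c(CC(C)(C)C(=O)O)n(Cc2ccc(Cl)cc2)c2ccc(OCc3ccc4cccnc4n3)cc12`) is reached from compound 2 by a single exchange on a saturated chain carbon bound to an oxygen on an aromatic ring: a group of 10 heavy atoms (8 carbon, 2 nitrogen; 2 six-membered aromatic rings with 1 hetero atom each) in place of a group of 12 heavy atoms (9 carbon, 1 nitrogen, 2 fluorine; one six-membered aromatic ring of carbon only, one six-membered aromatic ring with 1 hetero atom), on a saturated chain carbon bound to an oxygen on an aromatic ring. Among the measured compounds shown here, the one measured step that bears on this exchange, made at the same place, is a step that the two limits leave unreadable from compound 2 to compound 3. It offers no size to carry over and no direction to follow. Compound 1 differs from compound 2 in more than one place and adds only its limit. For the measured compounds named here, no step of readable size is therefore expected in this assay, and compound 4 is most likely to be reported at the same limit. The expected result is a step that the limit leaves unreadable from compound 2 to compound 4. For compound 4 the estimated value is 4000 nM, with an expected range of 1500 nM to 12000 nM.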

Compound 4, half-maximal inhibitory concentration: > 3000 nM
Compound 4 gave a limit, no number (the forecaster's own chance of this, stated with the estimate: 85%); the middle value does not contradict the limit.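

Compound 4, like compound 2 and compound 3, gives only a limit and not a number, so no step among these compounds can be read, and the series still comes down to one observation: the limit of > 3000 nM in this assay, at which 4 of the 4 values shown sit.

The compounds shown leave open whether any group on this saturated chain carbon bound to an oxygen on an aromatic ring would give a measurable value in this assay.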